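The source may report more compounds than this note shows. Statements on the series, on what has been measured and on what is new or still open speak of the compounds shown alone.

Among the measured compounds shown here, compound 1 `CCCc1nc(CC)c(C(=O)OCC(=O)c2ccccc2)n1Cc1ccc(-c2ccccc2S(=O)(=O)NC(=O)OCCC(C)C)cc1F` is the stronger-looking of the two compounds measured so far: in an assay on isolated protein for binding affinity to Type-2 angiotensin II receptor (Homo sapiens) (a higher number here means a weaker inhibitor, a lower number a stronger inhibitor), compound 1 gives 2 nM, the lowest of the two numbers, and its nearest neighbour is compound 2 `CCCc1nc(CC)c(C(=O)OC(C(=O)c2ccccc2)c2ccccc2)n1Cc1ccc(-c2ccccc2S(=O)(=O)NC(=O)OCCC(C)C)cc1F`, which in this assay gives 3 nM. For the measured compounds named here, the only measured step, a 1.5-fold higher number from compound 1 to compound 2 (0.18 log units; within the scatter), puts phenyl in place of hydrogen on a saturated chain carbon bound to a carbonyl carbon and an oxygen next to a carbonyl group, and it stays within the scatter.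

Compound 3 `CCCc1nc(CC)c(C(=O)OCCC[S+]([O-])c2ccccc2)n1Cc1ccc(-c2ccccc2S(=O)(=O)NC(=O)OCCC(C)C)cc1F` is not yet measured. It differs from compound 1 in that (a group of 10 heavy atoms (8 carbon, 1 oxygen, 1 sulfur; one six-membered aromatic ring of carbon only) in place of a group of 8 heavy atoms (7 carbon, 1 oxygen; one six-membered aromatic ring of carbon only), on a saturated chain carbon bound to an oxygen next to a carbonyl group). The measured step bears on this change only loosely: it alters the same ester-bearing region of the shared core, but it adds a phenyl rather than exchanging the benzoyl for a different group containing one aromatic ring and a sulfur. Since that one step, a 1.5-fold higher number from compound 1 to compound 2 (0.18 log units; within the scatter), stayed within the scatter, compound 3 is expected to land close to compound 1, with at most a modest move toward a higher number, a 2.0-fold higher number from compound 1 to compound 3 (0.30 log units; within the scatter). Compound 3 is therefore estimated at 4 nM in this assay, within a range from 1.5 nM to 12 nM.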

Compound 3, half-maximal inhibitory concentration: 1 nM
The estimate for compound 3 lay 4.0-fold (0.60 log units) above the measured number; measured number outside the range, below it.
By their numbers in this assay, from the lowest: compounds 3, 1 and 2 (each within the scatter of the next, the first and the last beyond it).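

In this assay, the exchange of benzoyl for the larger sulfur-bearing group gives a 2.0-fold lower number from compound 1 to compound 3 (0.30 log units; within the scatter), a step that stays within the scatter. The earlier step kept the benzoyl in place and only added a phenyl, whereas this one shows that the benzoyl itself can be replaced, on a saturated chain carbon bound to an oxygen next to a carbonyl group, without a change beyond the scatter; the ketone carbonyl of compound 1 is therefore not required for a number of this size, at least with this replacement, which keeps an aromatic ring and adds sulfur. Nothing available explains why the exchange is tolerated at this position.

The compounds shown do not separate the contributions of the sulfur, its oxygen and the aromatic ring, so it remains open whether a plain phenylpropyl chain would behave like compound 3. From the compounds shown here alone, it is also open whether a group without an aromatic ring at this place, such as a longer alkyl chain, an amine or a carboxylic acid, would stay within the scatter of compound 1.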